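A few compounds are considered here, and "the series" means these few. Any claim that something is new, unique, unknown or untested is made for them only; others in the source may bear on it.

Working notes on the amide series, all read in a functional assay on Hep 3B2 cells (Homo sapiens) for antiproliferative activity, read by MTT assay, with a stated time of 24 h, tested at 0.01 ug/mL; a higher number here means a stronger effect of the compound at the concentration tested, a lower number a weaker effect. Compound 1 `Cc1ccc2nc(C(=O)Nc3c(F)cc(-c4cccc(F)c4)cc3F)c(C)c(O)c2c1` gives 0.22% and compound 2 `COc1ccc2nc(C(=O)Nc3ccc(-c4ccccc4)cc3)c(C)c(O)c2c1` gives 0.35%. Compound 3 `Cc1ccc2nc(C(=O)Nc3c(F)cc(-c4cccc(F)c4)cc3F)c(C)c(C(=O)O)c2c1` gives 0.36%; this is the highest of the three numbers, but compound 2 and compound 1 both lie within the scatter of it, so no order among the three can be drawn. Going by the values given here, the only single-place step measured, a number 0.1 percentage points higher from compound 1 to compound 3 (within the scatter), is itself within the scatter. Compound 4 `COc1ccc2nc(C(=O)Nc3c(F)cc(-c4cccc(F)c4)cc3F)c(C)c(C(=O)O)c2c1` differs from compound 3 by methoxy in place of methyl on an aromatic carbon. Among the compounds with values here, compound 2 carries a methoxy and compound 3 a methyl on otherwise different amides, and their numbers coincide, so no measured step bears directly on this change. The step of a number 0.1 percentage points lower from compound 3 to compound 4 (within the scatter) is therefore expected to stay within the scatter. Compound 4 is estimated at 0.3%, with a range from 0% to 2%.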

Compound 4, a percentage reported as inhibition, at one concentration (the size of the read-out at that concentration, not a potency): -0.68%
Compound 4: middle estimate off by 1 percentage points, on the high side, and the stated range ends above it.
By their numbers in this assay, from the lowest: compounds 4, 1, 2 and 3 (each within the scatter of the next).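

Going by these compounds alone, on this aromatic carbon, methoxy in place of methyl gives a number 1 percentage points lower from compound 3 to compound 4 (within the scatter) in this assay as the first measured step at this position. Adding the oxygen and its hydrogen-bond acceptor therefore leaves the read-out within the scatter with the carboxy group and the fluorinated amide held constant. Nothing available explains the sign of the new value.

From the compounds shown here alone, whether a chloro or an ethoxy group on this carbon would move the read-out beyond the scatter stays open. Also open, going by these compounds, is whether methoxy and methyl stay this close with hydroxy in place of carboxy.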